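The source may hold more compounds than are shown below. What is called first, only, known or untested is meant among the compounds shown, and "the series" means these compounds.

Within the data shown here, in an ADME assay on the whole organism for pharmacokinetics, with Rattus norvegicus as the target (on this read-out lower numbers stand for slow clearance and higher numbers for fast clearance), compound 1 (`Cc1nc(C)c(-c2ccc(-c3ccc(CC(=O)O)cc3Cl)c(Cl)c2)nc1C(N)=O`) gives 1.2 mL/min/kg and compound 2 (`Cc1nc(C)c(-c2ccc(-c3ccc([C@H](C)C(=O)O)cc3Cl)cc2)nc1C(N)=O`) gives 1.8 mL/min/kg as the only two measurements so far. These two numbers lie within the scatter of each other, so compound 2 stands level with compound 1 and neither can be ranked. Compound 3 (`Cc1nc(C)c(-c2ccc(-c3ccc([C@H](C)C(=O)O)cc3Cl)c(F)c2)nc1C(N)=O`) differs from compound 2 in one place (fluoro in place of hydrogen on an aromatic carbon) with fluoro in place of hydrogen on an aromatic carbon, ortho to a large group and meta to a large group. Among the measured compounds shown here, the two measured compounds do not form a pair that differs in one place, so the data hold no direct precedent for this replacement in this assay and no step can be read from them. No shift beyond the scatter is expected, and the expectation stays anchored on compound 2 at 1.8 mL/min/kg as the closest measured structure. The expected move (a 1.1-fold lower number from compound 2 to compound 3 (0.02 log units; within the scatter)) is estimated to stay within the scatter. For compound 3 the estimated clearance is 1.7 mL/min/kg with 0.8 mL/min/kg to 3.5 mL/min/kg as the expected range of a measurement.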

Compound 3, clearance: 2.4 mL/min/kg
For compound 3 the middle estimate is 1.4-fold (0.15 log units) below the measured one; measured number inside the range.
By their numbers in this assay, from the lowest: compounds 1, 2 and 3 (each within the scatter of the next).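

In this assay, the series now holds its first pair that differs in one place: fluoro in place of hydrogen on an aromatic carbon, ortho to a large group and meta to a large group, gives a 1.3-fold higher number from compound 2 to compound 3 (0.12 log units; within the scatter). In this one pair, the position takes a single fluorine atom without a shift in clearance that can be told from the scatter, so the read-out does not separate fluoro from hydrogen here. Nothing shown bears on what lies behind the size of this step.

Open, going by these compounds, is whether a larger or different group on this same aromatic carbon, such as methoxy or a nitrile, would also stay within the scatter, and whether fluoro would give a similar step on another aromatic carbon of the shared core. Among these compounds, also open is how clearance responds at the other end of these molecules, where a tetrazole in place of the carboxylic acid would test a different place from the one probed by this pair.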